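Swapping Methoxy for Bromo in Compound 2

The source may hold more compounds than are shown below. What is called first, only, known or untested is meant among the compounds shown, and "the series" means these compounds.

Of the compounds shown here, two sharing one core have been measured so far. In a physicochemical assay, with a stated time of 30 min (on this read-out lower numbers stand for stronger inhibition and higher numbers for weaker inhibition), compound 1 (`CCc1ccc(NC(=O)C2Cc3cc(OC)c(OC)cc3C2=O)cc1`) gives 76.2 ug/mL and compound 2 (`COc1ccccc1NC(=O)C1Cc2cc(OC)c(OC)cc2C1=O`) gives 45.8 ug/mL. These two numbers lie within the scatter of each other, so compound 2 cannot be separated from compound 1 on this evidence.

Compound 3 (`COc1cc2c(cc1OC)C(=O)C(C(=O)Nc1ccccc1Br)C2`) is the next to be measured in this assay. It has bromo in place of methoxy on an aromatic carbon, ortho to a large group, turning 2-methoxyphenyl into 2-bromophenyl: bromo in place of methoxy on an aromatic carbon.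

For the measured compounds named here, only one measured step bears on this change. It exchanges the group on the same amide-type nitrogen and amounts to a 1.7-fold lower number from compound 1 to compound 2 (0.22 log units; within the scatter). Going by the values given here, no measured compound carries bromo, so the data say nothing direct about this exchange. That one step gives no reason to expect a shift beyond the scatter, nor a direction for one. The expected change is a 1.1-fold higher number from compound 2 to compound 3 (0.04 log units; within the scatter), which would remain within the scatter. Compound 3 is therefore estimated at 50 ug/mL, with an expected range from 22 ug/mL to 110 ug/mL.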

Compound 3, half-maximal inhibitory concentration: 65.4 ug/mL
Estimate against measurement, compound 3: 1.3-fold (0.12 log units) below; the measured number falls inside the stated range.
By their numbers in this assay, from the lowest: compounds 2, 3 and 1 (each within the scatter of the next).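

In this assay, the change from methoxy to bromo on an aromatic carbon, ortho to a large group, gives a 1.4-fold higher number from compound 2 to compound 3 (0.15 log units; within the scatter) and so stays within the scatter. For the compounds shown here, this is the first direct reading of an exchange at this position, and on this read-out it does not separate 2-bromophenyl from 2-methoxyphenyl. The wider exchange on the amide-type nitrogen, 2-bromophenyl in place of 4-ethylphenyl, gives a 1.2-fold lower number from compound 1 to compound 3 (0.07 log units; within the scatter) and is also within the scatter, so each of the three pairs among compound 1, compound 2 and compound 3 now lies within the scatter, and no measurement of any other kind accompanies this result to account for it.

The compounds shown leave open whether any group on this aromatic carbon can move the number beyond the scatter, since an amine, a carboxylic acid or a longer chain there would be a different kind of exchange from bromo for methoxy. They also leave open whether bromo would read the same on another carbon of this ring, or whether changes to the shared core would matter more than those on this ring.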